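The compounds below may be only part of what the source reports. "The series", "measured", "known", "first", "only" and "open" are said of these compounds alone.

Compound 1 `CC(C)N1C(=O)COc2ccc(-c3cnc(Cl)c(NS(=O)(=O)c4ccc(F)cc4)c3)cc21`: 25500 nM
Compound 2 `O=C1COc2ccc(-c3cccc(NS(=O)(=O)c4ccc(F)cc4)c3)cc2N1c1ccccc1`: > 40000 nM

Both compounds were tested in a functional assay on A-375 cells (Homo sapiens) for antiproliferative activity, read by MTT assay, with a stated time of 72 h; on this read-out lower numbers stand for stronger inhibition and higher numbers for weaker inhibition. Within the data shown here, compound 1 gives the only actual number, 25500 nM, and it sits in the weak range. For compound 2, > 40000 nM is a limit of the assay and not a number.

Compound 3 `O=C1COc2ccc(-c3cnc(Cl)c(NS(=O)(=O)c4ccc(F)cc4)c3)cc2N1c1ccc(Cl)cc1` keeps the core of compound 1 and differs in one place: 4-chlorophenyl in place of isopropyl on an amide-type nitrogen in a ring. Among the measured compounds shown here, no measured step shows what this change does in this assay. The expected step is a 1.3-fold lower number from compound 1 to compound 3 (0.11 log units; within the scatter), slightly toward stronger inhibition but none beyond the scatter. Compound 3 is expected at 20000 nM, with an estimated range of 7000 nM to 45000 nM.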

Compound 3, half-maximal inhibitory concentration: 30600 nM
Estimate against measurement, compound 3: 1.5-fold (0.18 log units) below, and the stated range covers the measured number.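

In this assay the change from isopropyl to 4-chlorophenyl on the amide-type nitrogen in a ring gives a 1.2-fold higher number from compound 1 to compound 3 (0.08 log units; within the scatter). Among these compounds, this is the first reading of a change at this position, and the large aromatic group reads the same as isopropyl, with both compounds staying in the weak range. Among the compounds shown here, compound 2 carries a limit and not a number, so it gives no step here: the limit of > 40000 nM in this assay, at which 1 of the 3 values shown sits.

On these data alone, whether an amine or a carboxylic acid on this nitrogen would read differently stays open. So does the effect of other groups on the rest of the core.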